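The compounds below may be only part of what the source reports. "The series", "measured", "known", "first", "only" and "open" are said of these compounds alone.

Measured so far in an ADME assay on MDBK cells (Bos taurus) for cytotoxicity; on this read-out lower numbers stand for higher toxicity in this test and higher numbers for lower toxicity in this test:

Compound 1 `Fc1ccccc1Cn1ccc2nc(-c3ccccc3)nc-2c1`: > 100000 nM (a limit of the assay)
Compound 2 `c1ccc(CCCCn2ccc3nc(-c4ccccc4)nc-3c2)cc1`: 95000 nM

Within the data shown here, compound 2, at 95000 nM in this assay, holds the only actual number so far. Compound 1 sits at a limit of the assay, (the limit of > 100000 nM in this assay, at which 1 of the 2 values shown sits), and that limit is not a number. Among the measured compounds shown here, no step between the two can therefore be stated.

Compound 3 `CCn1ccc2nc(-c3ccccc3)nc-2c1` has hydrogen in place of phenethyl on a saturated chain carbon, two bonds along the chain from an aromatic nitrogen, and the change is counted as hydrogen in place of phenethyl on a saturated chain carbon, two bonds along the chain from an aromatic nitrogen. For the measured compounds named here, no measured step shows what such a change does. With compound 2 at 95000 nM as the starting point, only a small step is expected in this assay, towards higher numbers if there is one at all, and it may well stay within the scatter. A report of the limit alone would not be a surprise. The estimated step of a 1.3-fold higher number from compound 2 to compound 3 (0.10 log units; within the scatter) is small. Compound 3 is expected at 120000 nM, with an estimated range from 50000 nM to 300000 nM.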

Compound 3, half-maximal cytotoxic concentration: > 100000 nM
Compound 3 gave a limit, no number; the forecaster's own chance of this, stated with the estimate: 65%; the middle value is on the limit's open side.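

In this assay, putting hydrogen in place of phenethyl on a saturated chain carbon, two bonds along the chain from an aromatic nitrogen, gives an at least 1.0-fold higher number from compound 2 to compound 3 (0.02 log units; that floor lies within the scatter). Among these compounds, this is the first step that can be read at this position, but it is only a floor within the scatter, so it shows no change in either direction, only that losing phenethyl and its aromatic ring brings no lower number here. The step from compound 1 to compound 3 cannot be read, and the results now rest mostly on a limit of the assay rather than on numbers: the limit of > 100000 nM in this assay, at which 2 of the 3 values shown sit.

The compounds shown leave open whether any group on this chain can bring a number clearly lower than the one compound 2 gives in this assay. They also do not tell what an amine or a carboxylic acid at the end of the chain, or a longer chain, would do to this read-out.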